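The compounds below may be only part of what the source reports. "The series", "measured", "known", "first", "only" and "open" are said of these compounds alone.

Measured so far in an assay (Rattus norvegicus) for inhibition of Fatty-acid amide hydrolase 1 (Homo sapiens); on this read-out lower numbers stand for stronger inhibition and higher numbers for weaker inhibition:
Compound 1 `N#Cc1ccc(-c2cnc(C(=O)CCCCCCc3ccccc3)o2)cc1` gives 40 nM.
Compound 2 `O=C(CCCCCCc1ccccc1)c1ncc(-c2ccncn2)o1` gives 2.3 nM.

Going by the values given here, compound 2 stands at the lowest number of the two; its only neighbour is compound 1, and the step of a 17-fold lower number from compound 1 to compound 2 (1.24 log units; beyond the scatter) came with pyrimidin-4-yl in place of 4-cyanophenyl on an aromatic carbon of the shared core. Compound 3 `O=C(CCCCCCc1ccccc1)c1ncc(-c2nnn[nH]2)o1` carries the change (1H-tetrazol-5-yl in place of pyrimidin-4-yl on an aromatic carbon), so the same position is altered again, now with a smaller five-membered group bearing a hydrogen-bond donor where the pyrimidin-4-yl had none. Among the compounds with values here, only one measured step bears on this position, and it concerned a different pair of groups, so it shows that the position tolerates large swings in this assay without saying in which direction a tetrazole would push. Compound 3 is therefore expected to stay in the same potent region as compound 2, with a modest drift toward a higher number and a wide range, amounting to an expected step of a 2.6-fold higher number from compound 2 to compound 3 (0.42 log units; beyond the scatter). Compound 3 is estimated at 6 nM, with a range from 1.5 nM to 30 nM.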

Compound 3, inhibition constant: 63 nM
For compound 3 the middle estimate is 11-fold (1.02 log units) below the measured one, and the stated range ends below it.
By their numbers in this assay, from the lowest: compound 2; then compounds 1 and 3 (each within the scatter of the next).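

In this assay, placing 1H-tetrazol-5-yl on the aromatic carbon next to the ring oxygen gives a 27-fold higher number from compound 2 to compound 3 (1.44 log units; beyond the scatter), so the low number of compound 2 does not extend to every aromatic ring containing nitrogen at this position. The second step, a 1.6-fold higher number from compound 1 to compound 3 (0.20 log units; within the scatter), shows no separation between 4-cyanophenyl and 1H-tetrazol-5-yl, even though these groups differ in ring size and in hydrogen-bond donors; among the three groups shown, only pyrimidin-4-yl stands apart, with the lowest number. No measurement is available that explains why these groups rank as they do in this assay.

The change from compound 2 to compound 3 alters ring size and adds a hydrogen-bond donor at once, so the compounds shown leave open which of these goes with the higher number. They also leave open whether the low number of compound 2 depends on the placement of the ring nitrogens, which a pyridin-4-yl or pyrimidin-5-yl group would test, and how a carboxylic acid would compare at the same carbon.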